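Methoxy for Methyl: Cytotoxicity of a Benzoxazole Amide

The compounds below may be only part of what the source reports. "The series", "measured", "known", "first", "only" and "open" are said of these compounds alone.

Compound 1 `Cc1ccc(-c2nc3ccccc3o2)cc1NC(=O)c1cc([N+](=O)[O-])ccc1Cl` was tested in an ADME assay on BJ cells (Homo sapiens) for cytotoxicity, with a stated time of 72 h; on this read-out lower numbers stand for an effect already at smaller amounts and higher numbers for an effect only at larger amounts of compound. Its result is a limit of the assay rather than a number: compound 1 gives > 14000 nM. Compound 2 `O=C(Nc1ccc(Cl)c(-c2nc3ccccc3s2)c1)c1cc([N+](=O)[O-])ccc1Cl` comes from the same study, and in this assay compound 2 also reaches only a limit, > 25000 nM. Because both results are limits, compound 1 stands at the limit of > 14000 nM in this assay, at which 1 of the 2 values shown sits, and no order between the two compounds can be read. Compound 3 `COc1ccc(-c2nc3ccccc3o2)cc1NC(=O)c1cc([N+](=O)[O-])ccc1Cl` differs from compound 1 in a single place: methoxy in place of methyl on an aromatic carbon. For the measured compounds named here, no measured pair shows what this change does, so the expectation for this assay rests on compound 1 alone. With both measured compounds at limits, the estimated step that the limit leaves unreadable from compound 1 to compound 3 is expected to stay within the scatter. Compound 3 is expected to give about 20000 nM, within 8000 nM to 50000 nM, most likely again as a limit.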

Compound 3, half-maximal effective concentration in the BJ assay: > 25000 nM
Compound 3: a limit, no number; the forecaster's own chance of this, stated with the estimate: 80%; at least 1.2-fold (0.09 log units) between middle value and limit.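

For the compounds shown here, compound 1 and compound 3 both give only limits in the BJ assay, and no step between them can be read. In a physicochemical assay for solubility, read by spectrophotometry, in phosphate buffer, measured as kinetic solubility, with a stated time of 18 h, at pH 7.4 (a lower number here means a less soluble compound, a higher number a more soluble compound), compound 1 gives 310 nM and compound 3 gives 90 nM. The compounds shown leave open what methoxy in place of methyl does to cytotoxicity in the BJ assay.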